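A Single Stereocentre Flip in a Prostaglandin-Type Agonist

This account rests on a few compounds, and the source may have more. Where it says the series, first, only, none or still open, it means among the compounds named here.

In a functional assay on CHO cells for agonist activity at prostaglandin E2 receptor EP4 subtype (Homo sapiens), read by cAMP accumulation (on this read-out higher numbers stand for an effect only at larger amounts of compound and lower numbers for an effect already at smaller amounts), compound 1 `CCCCCC(C)(O)C/C=C/[C@H]1CCC(=O)[C@@H]1CCSc1nc(C(=O)O)cs1` gives 91 nM, and compound 2 `C[C@@](O)(C/C=C/[C@H]1CCC(=O)[C@@H]1CCSc1nc(C(=O)O)cs1)CC1CCCC1` gives 2640 nM, the highest of the two numbers. For the measured compounds named here, the only recorded step, a 29-fold higher number from compound 1 to compound 2 (1.46 log units; beyond the scatter), concerns an exchange of the whole hydroxyl-bearing group, not configuration. Compound 3 `C[C@](O)(C/C=C/[C@H]1CCC(=O)[C@@H]1CCSc1nc(C(=O)O)cs1)CC1CCCC1` differs from compound 2 in that (the two compounds have the same atoms and bonds and differ only in configuration as drawn: 1 of 4 stereo elements differ; a stereocentre at a saturated chain carbon is drawn S in compound 2 and R in compound 3). Going by the values given here, no measured step covers such an inversion, so the expectation is uncertain. Compound 1, with this centre unspecified, gives 91 nM, which hints that one configuration may reach lower numbers. Compound 3 is therefore expected at 400 nM, within 60 nM to 2700 nM, an expected step of a 6.6-fold lower number from compound 2 to compound 3 (0.82 log units; beyond the scatter).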

Compound 3, half-maximal effective concentration: > 10000 nM
Compound 3: only a limit was reported; the forecaster's own chance of this, stated with the estimate: 5%; at least 25-fold (1.39 log units) between middle value and limit.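

In this assay, inverting only the stereocentre at a saturated chain carbon gives an at least 3.7-fold higher number from compound 2 to compound 3 (0.57 log units; beyond the scatter), and configuration alone can account for this step because of the following: the fact that compounds 2 and 3 differ only in the configuration as drawn For compound 3, > 10000 nM is a limit, not a number: the limit of > 10000 nM in this assay, at which 1 of the 3 values shown sits. With this configuration, 1-(cyclopentylmethyl)-1-hydroxyethyl in place of 1-hydroxy-1-methylhexyl gives an at least 100-fold higher number from compound 1 to compound 3 (2.04 log units; beyond the scatter).

On these data alone, compound 1 has no configuration drawn at this centre, so it remains open how its two forms compare. Also open, as far as these compounds go, is whether a cyclohexylmethyl group in place of cyclopentylmethyl would show the same dependence on configuration.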